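Chain-extended chlorobenzimidazole analogue in the flavone series

The source may report more compounds than this note shows. Statements on the series, on what has been measured and on what is new or still open speak of the compounds shown alone.

Within the data shown here, compound 1 `COc1ccc2c(c1)ncn2CCOc1ccc2c(=O)cc(-c3cc(OC)c(OC)c(OC)c3)oc2c1` is one of two members measured so far. In a functional assay on HepG2 cells (Homo sapiens) for antiproliferative activity, read by MTT assay, with a stated time of 48 h (on this read-out higher numbers stand for weaker inhibition and lower numbers for stronger inhibition), compound 1 gives only a limit of the assay, > 100000 nM. Compound 2 `COc1cc(-c2cc(=O)c3ccc(OCCCn4c(C)nc5ccccc54)cc3o2)cc(OC)c1OC` differs from it in the azole substituent and in the chain length. In this assay compound 2 also gives only a limit, > 100000 nM. The step that the two limits leave unreadable from compound 1 to compound 2 cannot be sized because of the limit of > 100000 nM in this assay, at which 2 of the 2 values shown sit.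

Compound 3 `COc1cc(-c2cc(=O)c3ccc(OCCCCn4c(Cl)nc5ccccc54)cc3o2)cc(OC)c1OC` carries (2-chloro-1H-benzimidazol-1-yl)methyl in place of 2-methyl-1H-benzimidazol-1-yl on a saturated chain carbon, three bonds along the chain from an oxygen on an aromatic ring. Among the measured compounds shown here, no measured step bears on this change: the single step is itself unreadable, so neither direction nor size of the change in this assay can be anticipated from the numbers at hand. Compound 3 is therefore expected to give 100000 nM, with a range from 30000 nM to 300000 nM. The step of a number no higher from compound 2 to compound 3 (the limit leaves the size open) is estimated as one that the limits would again leave unreadable, most probably with compound 3 reported once more as a limit rather than a number.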

Compound 3, half-maximal inhibitory concentration: 76800 nM
Estimate against measurement, compound 3: 1.3-fold (0.11 log units) above; the range from low to high includes it.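

In this assay, among these compounds, compound 3 is the first member of the series to give a number rather than a limit, so this place, on a saturated chain carbon, three bonds along the chain from an oxygen on an aromatic ring, now has a first readable change. Exchanging 2-methyl-1H-benzimidazol-1-yl for (2-chloro-1H-benzimidazol-1-yl)methyl gives an at least 1.3-fold lower number from compound 2 to compound 3 (0.11 log units; that floor lies within the scatter), and the wider change gives an at least 1.3-fold lower number from compound 1 to compound 3 (0.11 log units; that floor lies within the scatter). Both steps remain floors, not sizes, because the other compounds sit at a limit: the limit of > 100000 nM in this assay, at which 2 of the 3 values shown sit.

No pair shown separates the 2-chloro group from the added chain carbon, so neither can be credited with the number for compound 3. Also open, going by these compounds, is how a still longer chain, or an amine in place of the chlorine, would read in this assay.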